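The compounds below may be only part of what the source reports. "The series", "measured", "known", "first", "only" and "open" are said of these compounds alone.

Three compounds sharing one core have numbers in a functional assay on NCI-H460 cells (Homo sapiens) for cytotoxicity, read by MTT assay, with a stated time of 72 h; a higher number here means a weaker inhibitor, a lower number a stronger inhibitor. Compound 1 `CC(C)(C)c1[nH]cnc1/C=c1\[nH]c(=O)/c(=C/c2cccc(C(=O)c3ccc(F)cc3)c2)[nH]c1=O` gives 3.8 nM, compound 3 `CC(C)c1[nH]cnc1/C=c1\[nH]c(=O)/c(=C/c2cccc(C(=O)c3ccc(F)cc3)c2)[nH]c1=O` gives 3.2 nM, and compound 2 `CC(C)c1[nH]cnc1/C=c1\[nH]c(=O)/c(=C/c2cccc(Oc3ccc(F)cc3)c2)[nH]c1=O` gives 8.8 nM, the highest number of the three and so the weakest inhibitor among them.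

The step followed here leads to compound 4 `O=c1[nH]/c(=C\c2ccccn2)c(=O)[nH]/c1=C\c1cccc(Oc2ccc(F)cc2)c1`, which carries pyridin-2-yl in place of 5-isopropyl-1H-imidazol-4-yl on a double-bonded chain carbon bound to an aromatic carbon.

Going by the values given here, two measured steps bear on this only indirectly. Hydrogen in place of methyl on the saturated chain of the imidazole-bearing group gives a 1.2-fold lower number from compound 1 to compound 3 (0.07 log units; within the scatter), which lies within the scatter, but the ring itself stays. The change to (4-fluorophenyl)carbonyl gives a 2.8-fold lower number from compound 2 to compound 3 (0.44 log units; beyond the scatter), a modest step, but it concerns the 4-fluorophenoxy group, which compound 4 keeps. Among the compounds with values here, no measured compound lacks the imidazole ring, so the size of this replacement remains unmeasured. As it exchanges the whole group, a step larger than either of these is expected, towards a higher number in this assay, with wide uncertainty. The expected change is a 5.7-fold higher number from compound 2 to compound 4 (0.75 log units; beyond the scatter). For compound 4 the estimate is 50 nM, with an expected range of 10 nM to 300 nM.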

Compound 4, half-maximal inhibitory concentration: 49.1 nM
The estimate for compound 4 lay 1.0-fold (0.01 log units) above the measured number, and the stated range covers the measured number.
By their numbers in this assay, from the lowest: compounds 3 and 1 (each within the scatter of the next); then compound 2; then compound 4.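

Going by these compounds alone, with pyridin-2-yl in place of 5-isopropyl-1H-imidazol-4-yl on a double-bonded chain carbon bound to an aromatic carbon, this assay shows a 5.6-fold higher number from compound 2 to compound 4 (0.75 log units; beyond the scatter), so this position responds to an exchange of the whole group, whereas the earlier steps left the imidazole ring in place. Compound 4 still gives a low number at 49.1 nM, which shows that the imidazole ring and its isopropyl group can both be lost without the number leaving the range of this series. The entering group differs from the one that leaves in several counted ways at once, with one six-membered ring against one five-membered ring, 6 heavy atoms against 8, and 0 hydrogen-bond donors against 1, and nothing available here accounts for the step or assigns it to any one of these differences.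

The compounds shown leave open how much of the step belongs to the isopropyl group and how much to the ring, a question that an unsubstituted imidazole or an isopropyl-bearing pyridine would address. They also leave open whether pyridin-2-yl would produce a step of the same size alongside the (4-fluorophenyl)carbonyl group of compound 3.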